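Methoxy added to the hydroxyphenyl hydrazone of compound 3

This account rests on a few compounds, and the source may have more. Where it says the series, first, only, none or still open, it means among the compounds named here.

Measured so far:
compound 1 `C/C(=N\NC(=O)c1cccc(S(=O)(=O)N2CCOCC2)c1)c1cccc(N)c1O` — 530 nM
compound 2 `O=C(N/N=C/c1ccccn1)c1cccc(S(=O)(=O)N2CCOCC2)c1` — 81700 nM
compound 3 `O=C(N/N=C/c1ccccc1O)c1cccc(S(=O)(=O)N2CCOCC2)c1` — 25300 nM

All three were tested in a functional assay on MGC-803 cells (Homo sapiens) for antiproliferative activity, read by MTT assay, with a stated time of 72 h; a lower number here means a stronger inhibitor, a higher number a weaker inhibitor. Compound 3 stands second highest of the three numbers, well above compound 1 and nearer to compound 2. Going by the values given here, the only measured single-place step is a 3.2-fold lower number from compound 2 to compound 3 (0.51 log units; beyond the scatter), a change at a different place. Compound 4 `COc1ccc(/C=N/NC(=O)c2cccc(S(=O)(=O)N3CCOCC3)c2)c(O)c1` differs from compound 3 by methoxy in place of hydrogen on an aromatic carbon. Among the compounds with values here, no measured step touches this position, and compound 1 differs from compound 3 in several places at once, so nothing here fixes the direction. A small step is therefore expected, estimated as a 1.7-fold lower number from compound 3 to compound 4 (0.23 log units; within the scatter), with wide uncertainty. Compound 4 is expected to give about 15000 nM, within 4000 nM to 60000 nM.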

Compound 4, half-maximal inhibitory concentration: 2070 nM
Estimate against measurement, compound 4: 7.2-fold (0.86 log units) above, outside the stated range (below it).
By their numbers in this assay, from the lowest: compound 1; then compound 4; then compound 3; then compound 2.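

In this assay, going by these compounds alone, methoxy in place of hydrogen, on the aromatic carbon meta to a hydroxy group, gives a 12-fold lower number from compound 3 to compound 4 (1.09 log units; beyond the scatter) and so shows that this position, untouched by the earlier compounds, bears strongly on the read-out. Seen from the other side, 2-hydroxy-4-methoxyphenyl in place of pyridin-2-yl gives a 39-fold lower number from compound 2 to compound 4 (1.60 log units; beyond the scatter) and is a large step where 2-hydroxyphenyl alone gave a modest one. On these data alone, whether an amine, a carboxylic acid or a longer chain such as ethoxy on this carbon would keep the gain, and whether methoxy would count without the hydroxy group, stays open. Nothing measured here explains the step.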